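The source may hold more compounds than are shown below. What is called first, only, known or untested is meant among the compounds shown, and "the series" means these compounds.

The series shares one core, and compound 3 `CC(C)(C)C(=O)N(CCCCCCN1C[C@H](O)[C@@H](O)[C@H](O)[C@H]1CO)C1CCC1` is the point of departure for this account. In an ADME assay on Huh-7 cells (Homo sapiens) for cytotoxicity, read by MTT assay (a lower number here means that less compound is tolerated, a higher number that more compound is tolerated), compound 3 has no single number: the record reads "not determined" (no result reported), so its standing rests on its neighbours. Compound 1 `CC(C)(C)C(=O)N(CCCCCCN1C[C@H](O)[C@@H](O)[C@H](O)[C@H]1CO)C1CCCCC1` gives 500000 nM in this assay. Compound 2 `CC(C)(C)C(=O)N(CCCCCCN1C[C@H](O)[C@@H](O)[C@H](O)[C@H]1CO)c1ccc(F)cc1F` is recorded in this assay as a limit, > 500000 nM, not as a number. Among the measured compounds shown here, the one measured step, a number no lower from compound 1 to compound 2 (the limit leaves the size open), is therefore open in size, and its upper side is fixed by the limit of > 500000 nM in this assay, at which 1 of the 3 values shown sits. Compound 4 `CC(C)(C)C(=O)N(CCCCCCN1C[C@H](O)[C@@H](O)[C@H](O)[C@H]1CO)C1CCCCCCC1` differs from compound 3 only in cyclooctyl in place of cyclobutyl on an amide-type nitrogen. For the measured compounds named here, no measured step exchanges one carbocycle for another of a different size, so the cyclohexyl-to-difluorophenyl step is the only guide, and it shows tolerance running to the edge of what this assay reports. On that basis compound 4 is expected to sit in the same region of this assay, with a fair chance of another limit rather than a number. The estimated value for compound 4 in this assay is 450000 nM, with a range from 150000 nM to 600000 nM.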

Compound 4, half-maximal cytotoxic concentration: 150000 nM
The estimate for compound 4 lay 3.0-fold (0.48 log units) above the measured number, within the range that was stated.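

Until now, this position on the amide-type nitrogen had offered only a step of open size, but this assay now gives it a readable change between two saturated carbon rings: cyclooctyl in place of cyclohexyl brings a 3.3-fold lower number from compound 1 to compound 4 (0.52 log units; beyond the scatter). Among the compounds shown here, the same cyclooctyl group, set in place of 2,4-difluorophenyl, brings an at least 3.3-fold lower number from compound 2 to compound 4 (0.52 log units; beyond the scatter), so the position is not indifferent to the group it carries, and compound 4 is the first compound here to stand clearly lower than a neighbour. That second step has a size that is bounded on one side only, since compound 2 is recorded as a limit and not as a number: the limit of > 500000 nM in this assay, at which 1 of the 4 values shown sits.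

With compound 3 still lacking a number, cyclobutyl gives no third ring size, and two measured saturated rings cannot show whether the number falls steadily as the ring grows. On these data alone, how a cyclopentyl or cycloheptyl ring, an open hexyl chain, or a group carrying an amine or a carboxylic acid would stand at this place on the amide-type nitrogen also remains open.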